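The compounds below may be only part of what the source reports. "The series", "measured", "known", "first", "only" and "open" are said of these compounds alone.

Measured compounds:
Compound 1 `C=C(Br)C(=O)Nc1cccc(-c2cn3nc(-c4ccc(C)cc4)sc3n2)c1`: 1200 nM
Compound 2 `Nc1cccc(-c2cn3nc(-c4ccc(F)cc4)sc3n2)c1`: 33000 nM
Compound 3 `C=C(Br)C(=O)Nc1cccc(-c2cn3nc(-c4cccs4)sc3n2)c1`: 370 nM

These three compounds were tested in a functional assay on FM3A cells (Mus musculus) for inhibition, read by cell counting, with a stated time of 2 days; a lower number here means a stronger inhibitor, a higher number a weaker inhibitor. Compound 3 stands at the lowest number of the three: compound 1 sits above it by a 3.2-fold lower number from compound 1 to compound 3 (0.51 log units; beyond the scatter), and compound 2 is the furthest away, with a far higher number. The account now turns to compound 4 `C=C(Br)C(=O)Nc1cccc(-c2cn3nc(-c4ccc(F)cc4)sc3n2)c1`, which has not yet been measured in this assay. It differs from compound 3 in a single place: 4-fluorophenyl in place of thiophen-2-yl on an aromatic carbon. Among the compounds with values here, the one measured step that bears on this change is the one from compound 1 to compound 3, where a thiophen-2-yl group took the place of a 4-methylphenyl group and gave a 3.2-fold lower number from compound 1 to compound 3 (0.51 log units; beyond the scatter). Compound 4 moves in the opposite sense, putting a six-membered carbon ring back where compound 3 carries the five-membered ring, so a step of similar size in the other direction is expected: a modestly higher number in this assay than compound 3 shows. Compound 4 is therefore estimated at 1000 nM, with a range from 400 nM to 2500 nM, which means an expected step of a 2.7-fold higher number from compound 3 to compound 4 (0.43 log units; beyond the scatter).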

Compound 4, half-maximal inhibitory concentration: 610 nM
Compound 4: the middle estimate sits 1.6-fold (0.21 log units) above what was measured; measured number inside the range.
By their numbers in this assay, from the lowest: compounds 3, 4 and 1 (each within the scatter of the next, the first and the last beyond it); then compound 2.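

In this assay, exchanging the five-membered sulfur ring for a fluorinated six-membered carbon ring at this position, next to the ring nitrogen and the ring sulfur, gives a 1.6-fold higher number from compound 3 to compound 4 (0.22 log units; within the scatter), so thiophen-2-yl and 4-fluorophenyl cannot be told apart here. On the six-membered ring itself, the exchange of methyl for fluoro gives a 2.0-fold lower number from compound 1 to compound 4 (0.29 log units; within the scatter), so this small change at the far end of the aryl group also stays inside the usual variation between repeats. Within the data shown here, the first pair that isolates the nitrogen substituent with the aryl group held constant shows a much greater effect, with (1-bromoethenyl)carbonyl in place of hydrogen giving a 54-fold lower number from compound 2 to compound 4 (1.73 log units; beyond the scatter), which makes this the largest step among those read for compound 4.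

Nothing shown here offers a reason for any of these steps. From the compounds shown here alone, it also remains open how the number would respond if an amine or a carboxylic acid stood on the aryl ring at this position, or if a plain acetyl group replaced (1-bromoethenyl)carbonyl on the nitrogen.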